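Cyclic sulfonate series: cytotoxicity on HEL cells

The source may report more compounds than this note shows. Statements on the series, on what has been measured and on what is new or still open speak of the compounds shown alone.

Two members of the series have been run in an ADME assay on HEL cells (Homo sapiens) for cytotoxicity, with a stated time of 3 days (on this read-out higher numbers stand for lower toxicity in this test and lower numbers for higher toxicity in this test), and neither returned a number. Compound 1 `CC1(C(c2ccccc2)c2ccccc2)OS(=O)(=O)C=C1OCc1ccccc1` reached only the limit of >= 400000 nM in this assay, a limit of the measurement rather than a value. Compound 2 `CCC1(Cc2ccccc2)OS(=O)(=O)C=C1OCc1ccc(OC)cc1` likewise reached only the limit of >= 200000 nM in this assay, again a limit and not a number. Where compound 2 stands can therefore be said only as a bound: it sits at the limit described by the limit of >= 200000 nM in this assay, at which 1 of the 2 values shown sits, while the other member sits at the limit described by the limit of >= 400000 nM in this assay, at which 1 of the 2 values shown sits. Going by the values given here, no step between measured pairs that differ in one place exists in this set.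

Compound 3 `CCC1(Cc2ccccc2)OS(=O)(=O)C=C1OCc1ccc(Cl)c(Cl)c1` is the next member to be tested in this assay. It differs from compound 2 by 3,4-dichlorophenyl in place of 4-methoxyphenyl on a saturated chain carbon bound to an oxygen on an unsaturated carbon. Among the compounds with values here, with both known values being limits, no measured step is available for comparison, and the change is expected to move this assay by a modest step toward higher toxicity, or by nothing beyond the usual scatter. The estimated step is an at least 1.3-fold lower number from compound 2 to compound 3 (0.12 log units; that floor lies within the scatter). Compound 3 is expected to give about 150000 nM in this assay, within a range from 30000 nM to 400000 nM, with a fair chance that only a limit is again reported.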

Compound 3, minimum cytotoxic concentration: >= 20000 nM
Compound 3 was reported as a limit; the forecaster's own chance of this, stated with the estimate: 60%; the middle value does not contradict the limit.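

Compound 3 gives >= 20000 nM in this assay, which is a limit and not a number. Compound 2 also stands only as a limit, and the step between compound 2 and compound 3 cannot be read. The compounds shown leave open whether 3,4-dichlorophenyl in place of 4-methoxyphenyl changes this read-out at all.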